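The source may hold more compounds than are shown below. What is called first, only, known or untested is meant among the compounds shown, and "the series" means these compounds.

Measured in a functional assay on PC-3 cells (Homo sapiens) for inhibition, read by sulforhodamine B assay, with a stated time of 48 h (on this read-out lower numbers stand for stronger inhibition of growth and higher numbers for weaker inhibition of growth), each value a limit:
Compound 1 `CC(C)(C)NCc1c(C(=O)O)nn(-c2ccccc2)c1-c1ccc(Br)cc1`: > 585000 nM
Compound 2 `CC(C)(C)NCc1c(C(=O)O)nn(-c2ccccc2)c1-c1ccccc1`: > 716000 nM
Compound 3 `CC(C)(C)NCc1c(C(=O)O)nn(-c2ccccc2)c1-c1ccc([N+](=O)[O-])cc1`: > 634000 nM

Compound 2 stands only at a limit, with no number behind it, and the other two compounds are no different. Compound 4 `CC(C)(C)NCc1c(C(=O)O)nn(-c2ccc(Cl)cc2)c1-c1ccccc1` differs from compound 2 in one place: chloro in place of hydrogen on an aromatic carbon. Among the compounds with values here, the nearest measured steps, a step that the two limits leave unreadable from compound 1 to compound 2 and a step that the two limits leave unreadable from compound 2 to compound 3, cannot be sized, and none of the measured compounds carries chloro. Bromo, hydrogen and nitro all ended at limits, so no step beyond the scatter is expected in this assay, in either direction. The expected at least 1.1-fold lower number from compound 2 to compound 4 (0.04 log units; that floor lies within the scatter) therefore carries no real change. For compound 4 the estimate is 650000 nM, with an expected range of 300000 nM to 1000000 nM, most likely reported as a limit again.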

Compound 4, concentration for 50% growth inhibition: > 652000 nM
Compound 4 gave a limit, no number; the forecaster's own chance of this, stated with the estimate: 90%; middle value at least 1.0-fold (0.00 log units) away from the limit.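

Compound 2 and compound 4 both stand only at limits in this assay, and the step between them cannot be read. The compounds shown leave open whether chloro, bromo or nitro changes growth inhibition relative to hydrogen at all.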